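The source may hold more compounds than are shown below. What is called first, only, known or untested is meant among the compounds shown, and "the series" means these compounds.

Within the data shown here, in a functional assay on A2780 cells (Homo sapiens) for cytotoxicity, read by sulforhodamine B assay, with a stated time of 72 h (on this read-out lower numbers stand for stronger inhibition and higher numbers for weaker inhibition), compound 2 (`O=C(NCc1ccc(S(=O)(=O)N2CCC[C@@H](O)C2)cc1)N1Cc2ccncc2C1`) gives 70 nM, the higher of the two numbers measured so far, while compound 1 (`CCCn1cc(S(=O)(=O)c2ccc(CNC(=O)N3Cc4ccncc4C3)cc2)cn1`) gives 7.3 nM. Compound 3 (`O=C(NCc1ccc(S(=O)(=O)N2CC3(CCOCC3)C2)cc1)N1Cc2ccncc2C1`) keeps the shared core of compound 2 and differs only on the sulfonyl sulfur: a group of 9 heavy atoms (7 carbon, 1 nitrogen, 1 oxygen; one four-membered non-aromatic ring with 1 hetero atom, one six-membered non-aromatic ring with 1 hetero atom) in place of a group of 7 heavy atoms (5 carbon, 1 nitrogen, 1 oxygen; one six-membered non-aromatic ring with 1 hetero atom), on a sulfonyl sulfur. Among the measured compounds shown here, only one measured step bears on this place: a 9.6-fold higher number from compound 1 to compound 2 (0.98 log units; beyond the scatter), with 3-hydroxypiperidin-1-yl replacing 1-propyl-1H-pyrazol-4-yl. That step shows that the group on the sulfonyl sulfur can shift the number in this assay, but neither measured compound carries a four-membered ring, so it says nothing direct about the entering group. Compound 2 stands at the high end of the measured range at 70 nM, so a move towards lower numbers seems more likely than a further rise, though the evidence is thin. For the measured compounds named here, the expected change is a 2.8-fold lower number from compound 2 to compound 3 (0.45 log units; beyond the scatter), an estimate smaller than the one measured step. Compound 3 is therefore estimated at 25 nM, with an expected range from 6 nM to 100 nM.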

Compound 3, half-maximal inhibitory concentration: 10 nM
Beside the measured number, compound 3's estimate is 2.5-fold (0.40 log units) above it; the measured number falls inside the stated range.
By their numbers in this assay, from the lowest: compounds 1 and 3 (each within the scatter of the next); then compound 2.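

In this assay, the step of a 7.0-fold lower number from compound 2 to compound 3 (0.85 log units; beyond the scatter) shows that a large change in the number can occur between two non-aromatic groups attached through nitrogen to the sulfonyl sulfur, so the earlier contrast with the pyrazole does not simply separate aromatic from non-aromatic groups. The step of a 1.4-fold higher number from compound 1 to compound 3 (0.14 log units; within the scatter) places the entering group, with its four-membered and six-membered non-aromatic rings, level with 1-propyl-1H-pyrazol-4-yl in this assay, so among these three compounds a five-membered aromatic ring on the sulfonyl sulfur is not needed to reach the lower part of the measured range. No measurement shown here accounts for the shift.

The change from compound 2 to compound 3 alters several things at once, including the ring set, the heavy-atom count, the single hydrogen-bond donor and the defined stereocentre, and these compounds cannot show which of them matters. Going by these compounds, how a plain piperidin-1-yl or a plain azetidin-1-yl on the sulfonyl sulfur would read in this assay remains open, and either group would help to separate those features.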